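Removing the imidazolylmethyl arm from compound 1

This account rests on a few compounds, and the source may have more. Where it says the series, first, only, none or still open, it means among the compounds named here.

Compound 1 `Cc1ccc2c(NCc3ccc(NC(=O)C4CCN(Cc5ncc[nH]5)CC4)cc3)nc(N(C)C)nc2c1` is tested in a functional assay on SV5A8 cells (Homo sapiens) for cytotoxicity (a lower number here means a stronger inhibitor, a higher number a weaker inhibitor), and there compound 1 gives > 20000 nM, which is a limit of the assay rather than a number. That is the place compound 1 holds among the three measured compounds: it sits at the limit of > 20000 nM in this assay, at which 1 of the 3 values shown sits, and the other two values are limits as well. Compound 2 `Cc1ccc2c(NCc3ccc(NC(=O)C4CCN(Cc5ccccc5)CC4)cc3)nc(N3CCCC3)nc2c1` gives > 7790 nM in this assay, a limit. Compound 3 `Cc1ccc2c(NCc3ccc(NC(=O)C4CCN(Cc5ccccc5)CC4)cc3)nc(N3CCCCCC3)nc2c1` gives > 6880 nM in this assay, also a limit. Going by the values given here, the one step between measured compounds, a step that the two limits leave unreadable from compound 2 to compound 3, cannot be sized, since both ends are limits.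

Compound 4 `Cc1ccc2c(NCc3ccc(NC(=O)C4CCN(C)CC4)cc3)nc(N(C)C)nc2c1` differs from compound 1 by hydrogen in place of 1H-imidazol-2-yl on a saturated chain carbon bound to an amine nitrogen in a ring. No measured step follows this kind of change; the only step shown concerns a different part of the shared core and is unreadable. So there is no basis for expecting movement in either direction in this assay, and the three limits suggest compound 4 will most likely also come back as a limit. The expected step of a number no higher from compound 1 to compound 4 (the limit leaves the size open) is essentially none. Compound 4 is therefore estimated at 20000 nM, with a range from 7000 nM to 60000 nM.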

Compound 4, half-maximal inhibitory concentration: > 17300 nM
Compound 4: a limit, no number (the forecaster's own chance of this, stated with the estimate: 85%); the middle value lies beyond the limit too.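

In this assay compound 4 gives > 17300 nM, a limit of the assay and not a number. Compound 1 is also a limit, so the step between compound 1 and compound 4 cannot be read. The compounds shown leave open whether hydrogen in place of 1H-imidazol-2-yl changes the result in this assay at all, as none of the four gives a number.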